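The source may report more compounds than this note shows. Statements on the series, on what has been measured and on what is new or still open speak of the compounds shown alone.

The four compounds share one core, a substituted aminocyclopentane attached through a nitrogen to an aromatic ring system; its structure stands beside each compound. Compound 1 `Nc1nc(Cl)c(-c2ncco2)c(N[C@@H]2C[C@H](CO)[C@@H](O)[C@H]2O)n1`, compound 2 `Nc1nc(Cl)c(-c2nc3ccc(F)cc3s2)c(N[C@@H]2C[C@H](CO)[C@@H](O)[C@H]2O)n1` and compound 3 `Cc1nc(NCC2CCC2)nc(N[C@@H]2C[C@H](CO)[C@@H](O)[C@H]2O)c1-c1nc2ccccc2s1` have been run in an ADME assay on cells (Homo sapiens) for cytotoxicity, read by polymerase chain reaction, with a stated time of 3 days; on this read-out lower numbers stand for higher toxicity in this test and higher numbers for lower toxicity in this test. In this assay compound 1 gives only the limit of > 25000 nM, not a number. In this assay compound 2 likewise stops at the limit of > 25000 nM. In this assay compound 3 also returns the limit of > 25000 nM and no number. Among the compounds with values here, compound 3 thus stands where every value so far stands: the limit of > 25000 nM in this assay, at which 3 of the 3 values shown sit, so no order among the three can be read, and no step between measured compounds exists.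

Compound 4 `Cc1nc(NCc2ccsc2)nc(N[C@@H]2C[C@H](CO)[C@@H](O)[C@H]2O)c1-c1nc2ccccc2s1` differs from compound 3 in one place: thiophen-3-yl in place of cyclobutyl on a saturated chain carbon bound to a nitrogen on an aromatic ring. Within the data shown here, no measured pair shows what this change does in this assay, so the expectation rests on the position of compounds 1, 2 and 3 at the limit (the limit of > 25000 nM in this assay, at which 3 of the 3 values shown sit). The step in this assay is expected to be none beyond the scatter, a step that the limit leaves unreadable from compound 3 to compound 4. Compound 4 is estimated at 30000 nM in this assay, within a range from 15000 nM to 60000 nM, and the measurement is most likely to return only a limit again.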

Compound 4, half-maximal cytotoxic concentration: 6000 nM
The estimate for compound 4 lay 5.0-fold (0.70 log units) above the measured number; measured number outside the range, below it.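

In this assay, within the data shown here, thiophen-3-yl in place of cyclobutyl on a saturated chain carbon bound to a nitrogen on an aromatic ring gives an at least 4.1-fold lower number from compound 3 to compound 4 (0.61 log units; beyond the scatter), so a change at this place can bring the read-out down from the limit, which the earlier compounds could not show. Among these compounds, compound 4 gives 6000 nM, the only actual number in the set, so the series now has a measurable toxicity signal in this test. That signal rests on a single compound, and the others offer no number to set it against: the limit of > 25000 nM in this assay, at which 3 of the 4 values shown sit.

Because compound 3 stands at a limit, the full size of the step stays unknown, and no other step among the compounds shown can be read. Also open, on these data alone, is whether a phenyl or a furan-3-yl on the same chain carbon would give a number near that of compound 4 or return to the limit, which would indicate whether the signal follows aromatic rings at this place generally or thiophen-3-yl in particular.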